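A Methoxy Group Removed from Compound 1

The compounds below may be only part of what the source reports. "The series", "measured", "known", "first", "only" and "open" are said of these compounds alone.

Compound 1 `COc1cc(CCCCC(=O)/C=C/c2ccc(O)cc2)ccc1O` was examined in an ADME assay on HT-22 cells (Mus musculus) for cytotoxicity, read by MTT assay, with a stated time of 24 h, tested at 10 uM (on this read-out lower numbers stand for a stronger effect and higher numbers for a weaker effect at the one concentration tested), where compound 1 gives 67%. That is the highest of the two numbers recorded. The nearest is compound 2 `Oc1ccc(CCCCC(O)CCc2ccc(O)cc2)cc1`, for which a value of 43% is reported, a gap that lies beyond the usual scatter of repeated measurements of this kind. Compound 3 `O=C(/C=C/c1ccc(O)cc1)CCCCc1ccc(O)cc1` has not yet been measured in this assay. It differs from compound 1 in a single place: hydrogen in place of methoxy on an aromatic carbon. Within the data shown here, no pair of measured compounds shows this particular change, so the data give no direct guide to its effect. Compound 2 differs from compound 1 in several places at once, and its lower number cannot be tied to any one of them. Among the measured compounds shown here, with no step of this kind among the measured compounds, the expectation for compound 3 rests on compound 1 alone, and the step is estimated to be small, in either direction, and most likely within the scatter: a number 2 percentage points lower from compound 1 to compound 3 (within the scatter). Compound 3 is therefore expected to give about 65% in this assay, with a range from 50% to 80%.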

Compound 3, a percentage reported as activity, at one concentration (the size of the read-out at that concentration, not a potency): 43%
For compound 3 the middle estimate is 22 percentage points above the measured one, outside the stated range (below it).
By their numbers in this assay, from the lowest: compounds 2 and 3 (each within the scatter of the next); then compound 1.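

In this assay, the position ortho to a hydroxy group proves sensitive to substitution: hydrogen in place of methoxy on this aromatic carbon gives a number 24 percentage points lower from compound 1 to compound 3 (beyond the scatter) and moves the number towards the stronger-effect end of the read-out. Until now, no number could be tied to this position, as compound 2 differs from compound 1 in several places at once, whereas this single change isolates the methoxy group and shows that its loss alone can shift the result by more than the usual scatter. No measurement presented here bears on the reason for this step.

The compounds shown leave open whether another group on the same aromatic carbon, such as an ethoxy group or a fluorine atom, would give a number nearer that of compound 1 or that of compound 3. They also leave open whether the same change would give a similar step at other concentrations, or on a core carrying a longer chain.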